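This account rests on a few compounds, and the source may have more. Where it says the series, first, only, none or still open, it means among the compounds named here.

Of the compounds shown here, two have been measured so far. Compound 1, `CC(C)(C)OC(=O)NCCCNC(=O)CN1CN(c2ccccc2)C2(CCN(C(=O)c3ccc(C4CCCCC4)cc3)CC2)C1=O`, carries a chain ending in a tert-butoxycarbonyl-protected amine, and in an assay on HEK293 cells for displacement of a labelled ligand from NPC1-like intracellular cholesterol transporter 1 (Homo sapiens) (on this read-out lower numbers stand for stronger inhibition and higher numbers for weaker inhibition), compound 1 gives 6000 nM. Compound 2, `CC(C)(C)OC(=O)N1CCN(C(=O)CN2CN(c3ccccc3)C3(CCN(C(=O)c4ccc(C5CCCCC5)cc4)CC3)C2=O)CC1`, closes that chain into a six-membered ring with two nitrogen atoms, the tert-butoxycarbonyl now sitting on the ring nitrogen, and in this assay compound 2 gives 3500 nM. On the numbers shown, compound 2 stands at the lower of the two values, but its nearest neighbour, compound 1, lies within the scatter of it, so the two cannot be told apart.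

Compound 3, `CS(=O)(=O)N1CCN(C(=O)CN2CN(c3ccccc3)C3(CCN(C(=O)c4ccc(C5CCCCC5)cc4)CC3)C2=O)CC1`, is the next member, not yet measured in this assay. It differs from compound 2 in one place: methylsulfonyl in place of tert-butoxycarbonyl on an amine nitrogen in a ring. Among the compounds with values here, no measured pair of this kind exists here, so the size of the step is open. Compound 3 is expected to land close to compound 2 in this assay, with a step of a 1.1-fold higher number from compound 2 to compound 3 (0.06 log units; within the scatter) that need not exceed the scatter. Compound 3 is thus estimated at 4000 nM in this assay, within a range from 1500 nM to 12000 nM.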

Compound 3, half-maximal inhibitory concentration: 6300 nM
For compound 3 the middle estimate is 1.6-fold (0.20 log units) below the measured one, and the stated range covers the measured number.
By their numbers in this assay, from the lowest: compounds 2, 1 and 3 (each within the scatter of the next).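

At the amine nitrogen in the six-membered ring with 2 nitrogen, the exchange of tert-butoxycarbonyl (7 heavy atoms) for methylsulfonyl (4 heavy atoms) gives, in this assay, a 1.8-fold higher number from compound 2 to compound 3 (0.26 log units; within the scatter) and so leaves the two compounds indistinguishable. The larger exchange on the carbonyl carbon, 4-(methylsulfonyl)piperazin-1-yl in place of (3-((tert-butoxycarbonyl)amino)propyl)amino, gives a 1.1-fold higher number from compound 1 to compound 3 (0.02 log units; within the scatter) and likewise separates nothing, so compound 3, which has no tert-butoxycarbonyl, sits within the scatter of both compounds that carry one. Nothing shown gives a reason why these numbers stay so close together.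

On these data alone, it remains open whether any group on this ring nitrogen can move the number beyond the scatter, for instance a free amine, an acetyl, a benzoyl or a longer sulfonyl chain such as ethylsulfonyl. As far as these compounds go, it is equally open whether a carboxylic acid at the end of the chain on the carbonyl carbon would behave as these three compounds do in this assay or would separate from them.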